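From pyridin-3-yl to pyridin-2-yl on a carbonyl carbon

The compounds below may be only part of what the source reports. "The series", "measured", "known", "first", "only" and "open" are said of these compounds alone.

Values in a functional assay on MDA-MB-231 cells (Homo sapiens) for antiproliferative activity, with a stated time of 4 days; on this read-out higher numbers stand for weaker inhibition and lower numbers for stronger inhibition:
Compound 1 `CCCCc1ccc2[nH]c(-c3ccc(OC)cc3)c(/C=N/NC(=O)c3ccc(Cl)cc3)c2c1`: 90 nM
Compound 2 `CCCCc1ccc2[nH]c(-c3ccc(OC)cc3)c(/C=N/NC(=O)c3ccc(F)cc3)c2c1`: 19 nM
Compound 3 `CCCCc1ccc2[nH]c(-c3ccc(OC)cc3)c(/C=N/NC(=O)c3cccnc3)c2c1`: 35 nM

Compound 3 stands level with compound 2 and apart from compound 1. The numbers show a 1.8-fold higher number from compound 2 to compound 3 (0.27 log units; within the scatter), and they show a 2.6-fold lower number from compound 1 to compound 3 (0.41 log units; beyond the scatter).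

Compound 4 `CCCCc1ccc2[nH]c(-c3ccc(OC)cc3)c(/C=N/NC(=O)c3ccccn3)c2c1` has the same atoms as compound 3, joined differently: pyridin-2-yl in place of pyridin-3-yl on a carbonyl carbon. In short, pyridin-2-yl stands in place of pyridin-3-yl on a carbonyl carbon.

Among the compounds with values here, no measured step makes this exact exchange, so the evidence is indirect. The closest steps are the two replacements at the same carbonyl carbon given above, one within the scatter and one only modest. The remaining step, a 4.7-fold lower number from compound 1 to compound 2 (0.68 log units; beyond the scatter), is also modest, and it shows that a single aromatic replacement can matter in this small set. A small step at most is therefore expected in this assay, with no confident direction.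

The expected step is a 1.1-fold higher number from compound 3 to compound 4 (0.06 log units; within the scatter).

For compound 4 the estimated value is 40 nM, with an expected range of 14 nM to 110 nM.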

Compound 4, half-maximal inhibitory concentration: 34 nM
For compound 4 the middle estimate is 1.2-fold (0.07 log units) above the measured one, and the stated range covers the measured number.
By their numbers in this assay, from the lowest: compounds 2, 4 and 3 (each within the scatter of the next); then compound 1.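

In this assay, the pyridine nitrogen's placement does not register at this position: with pyridin-2-yl in place of pyridin-3-yl on the carbonyl carbon, the step is a 1.0-fold lower number from compound 3 to compound 4 (0.01 log units; within the scatter). The second pyridine also repeats the pattern of the first against the two halogenated rings, with a 1.8-fold higher number from compound 2 to compound 4 (0.25 log units; within the scatter) against 4-fluorophenyl and a 2.6-fold lower number from compound 1 to compound 4 (0.42 log units; beyond the scatter) against 4-chlorophenyl, so the two pyridines are alike in both comparisons. Nothing shown here accounts for this outcome.

The compounds shown leave open whether pyridin-4-yl, or a saturated amine such as piperidin-4-yl, on the same carbonyl carbon would stay level with these pyridines. They also leave open how a carboxylic acid on the phenyl ring would read in this assay.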